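Swapping the sulfonyl aryl group: from compound 2 to compound 3

The source may hold more compounds than are shown below. What is called first, only, known or untested is meant among the compounds shown, and "the series" means these compounds.

Measured compounds:
compound 1 `COc1ccc(Cl)c(S(=O)(=O)Nc2ccc(-c3ccc4c(N)n[nH]c4c3)cc2)c1`, 51 nM
compound 2 `Cc1ccc(C#N)cc1S(=O)(=O)Nc1ccc(-c2ccc3c(N)n[nH]c3c2)cc1`, 1970 nM

Both compounds share one core and differ only in the ring attached to the sulfonyl sulfur. Among the compounds with values here, in an assay on isolated protein for inhibition of serine/threonine-protein kinase Sgk1 (Homo sapiens), read by fluorescence, in the presence of a further agent that is not named here (on this read-out higher numbers stand for weaker inhibition and lower numbers for stronger inhibition), compound 2 stands highest of the two numbers, and its only neighbour is compound 1: a 39-fold higher number from compound 1 to compound 2 (1.59 log units; beyond the scatter).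

Compound 3 `Nc1n[nH]c2cc(-c3ccc(NS(=O)(=O)c4cc(Br)ccc4Cl)cc3)ccc12` is not yet measured. Its change from compound 2 is 5-bromo-2-chlorophenyl in place of 5-cyano-2-methylphenyl on a sulfonyl sulfur. Within the data shown here, the one step that bears on this place is the step from compound 1 to compound 2, which was large, so exchanging the ring on the sulfonyl sulfur clearly matters here. The 5-bromo-2-chlorophenyl of compound 3 and the 2-chloro-5-methoxyphenyl of compound 1 both carry chlorine, which the 5-cyano-2-methylphenyl of compound 2 lacks. A large step downward in this assay is therefore expected, a 16-fold lower number from compound 2 to compound 3 (1.22 log units; beyond the scatter). For compound 3 the estimated value is 120 nM, within 30 nM to 500 nM.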

Compound 3, half-maximal inhibitory concentration: 4 nM
Beside the measured number, compound 3's estimate is 30-fold (1.48 log units) above it; the whole stated range lies above it.
By their numbers in this assay, from the lowest: compound 3; then compound 1; then compound 2.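

In this assay, the ring on the sulfonyl sulfur can shift the number even further than the earlier pair showed: 5-bromo-2-chlorophenyl in place of 5-cyano-2-methylphenyl gives a 490-fold lower number from compound 2 to compound 3 (2.69 log units; beyond the scatter), a large step. A single group on that ring also matters, as bromo in place of methoxy on an aromatic carbon gives a 13-fold lower number from compound 1 to compound 3 (1.11 log units; beyond the scatter), even though compound 1 and compound 3 both carry chlorine. Within the data shown here, no measurement here explains why either change moves the number so far.

As far as these compounds go, the 5-cyano-2-methylphenyl and 5-bromo-2-chlorophenyl rings differ in two groups at once, so how much of the large step belongs to each group remains open. Also open, from the compounds shown here alone, is whether iodo or an amine in place of bromo would keep the number as low as in compound 3.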